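A few compounds are considered here, and "the series" means these few. Any claim that something is new, unique, unknown or untested is made for them only; others in the source may bear on it.

Compound 3 `CC(=O)N1c2ccc(-c3ccc(S(C)(=O)=O)cc3)cc2N(C(=O)OC(C)C)C[C@@H]1C` gives 99% in an ADME assay on microsomes from liver (Mus musculus) for metabolic stability, with a stated time of 30 min (a higher number here means that more of the compound is left, a lower number that less of the compound is left), the highest of the three measured numbers, with compound 1 `C[C@H]1CN(C(=O)c2ccco2)c2cc(-c3ccc(S(C)(=O)=O)cc3)ccc2N1C(=O)C1CC1` at 19% and compound 2 `CCC(=O)N1c2ccc(-c3ccc(S(C)(=O)=O)cc3)cc2N(C(=O)c2ccco2)C[C@@H]1C` at 11% both far beneath it. Compound 4 `CC(=O)N1c2ccc(-c3ccc(S(C)(=O)=O)cc3)cc2N(C(=O)C2CC2)C[C@@H]1C` differs from compound 3 by cyclopropyl in place of isopropoxy on a carbonyl carbon, turning the isopropoxycarbonyl into a cyclopropylcarbonyl. Among the compounds with values here, no measured step covers this exchange; the only single step known, a number 8 percentage points lower from compound 1 to compound 2 (within the scatter), concerns the other carbonyl and lies within the scatter, so it gives little guidance. With the carbamate removed, a downward step is expected for compound 4, as a number 34 percentage points lower from compound 3 to compound 4 (beyond the scatter). Compound 4 is therefore estimated at 65%, between 30% and 95%.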

Compound 4, percent of the compound remaining: 100%
Compound 4: the middle estimate sits 35 percentage points below what was measured; the measured number lies above the stated range.
By their numbers in this assay, from the lowest: compounds 2 and 1 (each within the scatter of the next); then compounds 3 and 4 (each within the scatter of the next).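

In this assay, cyclopropyl in place of isopropoxy on a carbonyl carbon gives a number 1 percentage points higher from compound 3 to compound 4 (within the scatter) and so leaves the read-out unchanged within the scatter. At this position, therefore, the isopropoxycarbonyl can give way to the cyclopropylcarbonyl, and the oxygen of the isopropoxy is not needed to keep the number high. Nothing available explains why the two groups read alike. Still open, from the compounds shown here alone, is whether an amine or a carboxylic acid on this carbonyl would hold the number, and whether the exchange reads the same when the other carbonyl carries a longer chain.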